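This account rests on a few compounds, and the source may have more. Where it says the series, first, only, none or still open, it means among the compounds named here.

Working notes on the benzamide series. For the measured compounds named here, compound 1 `COc1ccccc1C(=O)NCCNc1cccc(NS(=O)(=O)c2cc(-c3cccc(C(=O)N(C)C)c3)ccc2OC)c1` is the only member with a number: in a functional assay on CHO-K1 cells for agonist activity at Orexin/Hypocretin receptor type 1 (Homo sapiens), read by calcium flux (on this read-out higher numbers stand for an effect only at larger amounts of compound and lower numbers for an effect already at smaller amounts), compound 1 gives 5230 nM. Compound 2 `COc1ccc(-c2cccc(C(=O)N(C)C)c2)cc1S(=O)(=O)Nc1cccc(NCCNC(=O)c2ccccc2)c1` carries an unsubstituted benzamide in place of the methoxy-substituted one of compound 1; in this assay the entry for compound 2 reads "not determined" (no result reported), so it stands without a number. The same holds for compound 3 `COc1ccc(-c2cccc(C(=O)N(C)C)c2)cc1S(=O)(=O)Nc1cccc(NCCNC(=O)c2ccccc2C)c1`, which bears a methyl on the benzamide ring and whose entry in this assay likewise reads "not determined" (no result reported).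

Compound 4 `COc1ccc(-c2cccc(C(=O)N(C)C)c2)cc1S(=O)(=O)Nc1cccc(NCCNC(=O)c2ccccc2Cl)c1` is the next member to be run in this assay. Relative to compound 2 the change is chloro in place of hydrogen on an aromatic carbon. Going by the values given here, no step between measured compounds exists that would size this change; the only anchor is compound 1, whose benzamide also carries a single substituent and which gives 5230 nM in this assay. On that basis compound 4 is expected to fall in the same micromolar region, with wide uncertainty: the estimate for compound 4 in this assay is 4500 nM, within a range from 1200 nM to 20000 nM.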

Compound 4, half-maximal effective concentration: 6130 nM
The estimate for compound 4 lay 1.4-fold (0.13 log units) below the measured number, and the stated range covers the measured number.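

Compound 4 gives the series its first readable step: with chloro in place of methoxy on the aromatic carbon ortho to a large group, this assay shows a 1.2-fold higher number from compound 1 to compound 4 (0.07 log units; within the scatter). At this place, therefore, the read-out does not separate these two substituents, and the pair gives a first sign that this position tolerates more than one single-atom or small group without leaving the same region. Nothing at hand explains this result.

As far as these compounds go, the steps from hydrogen cannot be read, so whether any substituent at this place matters compared with the unsubstituted benzamide of compound 2 remains open. Also open, from the compounds shown here alone, is whether a group of another kind on this carbon, such as an amine or a carboxylic acid, would stay in the same region.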